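From 2-methoxyphenyl to 4-methoxyphenyl in compound 3

The source may report more compounds than this note shows. Statements on the series, on what has been measured and on what is new or still open speak of the compounds shown alone.

Going by the values given here, in a functional assay on COLO 205 cells (Homo sapiens) for inhibition, read by sulforhodamine B assay, with a stated time of 48 h, tested at 50 uM (on this read-out lower numbers stand for less inhibition of growth and higher numbers for more inhibition of growth at the one concentration tested), compound 2 `COc1ccccc1/C=C/C(=O)/C=C/c1ccc(OCc2cn(CCCCOc3cc(=O)oc4ccccc34)nn2)c(OC)c1` gives 47% and stands within the scatter of the only other measured compound, compound 1 `COc1cccc(/C=C/C(=O)/C=C/c2ccc(OCc3cn(CCCCOc4cc(=O)oc5ccccc45)nn3)c(OC)c2)c1` at 46% on the same read-out. Compound 3 `COc1ccc(/C=C/C(=O)/C=C/c2ccc(OCc3cn(CCCCOc4cc(=O)oc5ccccc45)nn3)c(OC)c2)cc1` carries 4-methoxyphenyl in place of 2-methoxyphenyl on a double-bonded chain carbon bound to a double-bonded chain carbon. Among the compounds with values here, the only measured step at this place is a number 1 percentage points higher from compound 1 to compound 2 (within the scatter) for 2-methoxyphenyl in place of 3-methoxyphenyl. In this assay, within the data shown here, no step beyond the scatter is therefore expected, and no direction can be favoured, although no measured compound yet carries 4-methoxyphenyl and a single step is thin evidence. The estimated change is no change at the digits printed from compound 2 to compound 3 (within the scatter) as a working expectation. The value estimated for compound 3 is 47% with an expected range from 34% to 60% in this estimate.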

Compound 3, percent growth inhibition at one concentration: 49%
The estimate for compound 3 lay 2 percentage points below the measured number; the range from low to high includes it.
By their numbers in this assay, from the lowest: compounds 1, 2 and 3 (each within the scatter of the next).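

With 4-methoxyphenyl in place, all three placements of the methoxy group on this phenyl now have a number, and this assay gives a number 2 percentage points higher from compound 2 to compound 3 (within the scatter) and a number 3 percentage points higher from compound 1 to compound 3 (within the scatter). Neither step leaves the scatter, so 2-methoxyphenyl, 3-methoxyphenyl and 4-methoxyphenyl on a double-bonded chain carbon bound to a double-bonded chain carbon cannot be told apart on this read-out at the one concentration tested. Nothing available bears on why these three compounds read alike.

Going by these compounds, what stays open is whether this place responds to anything other than a methoxyphenyl, such as a phenyl bearing an amine or a carboxylic acid, or a longer alkoxy chain in place of the methoxy. On these data alone, it is also open whether the three compounds would still read alike at other concentrations.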